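Adding a Second Chloro to a Rearranged Core

A few compounds are considered here, and "the series" means these few. Any claim that something is new, unique, unknown or untested is made for them only; others in the source may bear on it.

Compound 1 `ClCc1cccc(Cn2cnc3c(Cl)ncnc32)c1` and compound 2 `ClCc1cccc(Cn2cnc3c(Cl)nc(Cl)nc32)c1` share one core, and in a functional assay on Hs-578T cells (Homo sapiens) for cytotoxicity, read by sulforhodamine B assay, with a stated time of 48 h (a lower number here means a stronger inhibitor of growth, a higher number a weaker inhibitor of growth), compound 1 gives 11500 nM. In this assay compound 2 gives 4360 nM. Within the data shown here, the single change between the two, (chloro in place of hydrogen on an aromatic carbon), made a 2.6-fold lower number from compound 1 to compound 2 (0.42 log units; beyond the scatter). Compound 3 `ClCc1ccccc1Cn1cnc2ncnc(Cl)c21` is built from the same atoms as compound 1, joined differently; the difference between the two cores is not broken down here. In this assay compound 3 gives 6020 nM, a number that sits within the scatter of compound 2 and also of compound 1. Compound 4 `ClCc1ccccc1Cn1cnc2nc(Cl)nc(Cl)c21` has not yet been measured. It differs from compound 3 by chloro in place of hydrogen on an aromatic carbon, which is the same change that turns compound 1 into compound 2, with the same surroundings in both cases. That change has been seen only once among the measured compounds, so any expectation rests on that single pair. Because a 2.6-fold lower number from compound 1 to compound 2 (0.42 log units; beyond the scatter), compound 4 is expected to show a 2.6-fold lower number from compound 3 to compound 4 (0.42 log units; beyond the scatter) in this assay. Compound 4 is therefore estimated at 2300 nM, with a likely range from 1200 nM to 4500 nM.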

Compound 4, concentration for total growth inhibition: 2570 nM
The estimate for compound 4 lay 1.1-fold (0.05 log units) below the measured number, and the stated range covers the measured number.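

In this assay, chloro in place of hydrogen on the core of compound 3 gave a 2.3-fold lower number from compound 3 to compound 4 (0.37 log units; beyond the scatter), so the change carried over to a second core with the same direction and a matching size: the same change on two cores in this assay, a 2.6-fold lower number (0.42 log units; beyond the scatter) from compound 1 to compound 2 and a 2.3-fold lower number (0.37 log units; beyond the scatter) from compound 3 to compound 4, 1.1-fold (0.05 log units) apart, within the scatter of two such steps. For these two pairs, then, the step measured on one core served as a fair guide to the step on the other. Among these compounds, it does not show that the change would behave alike on any further core, as the finding rests on only two pairs in a single cell assay, and it gives no explanation of how the chloro acts.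

The compounds shown leave open whether an amine or a methoxy group on that same aromatic carbon, between two ring nitrogen atoms, would shift the number in the same way. Also open, as far as these compounds go, is what the chloromethyl group, common to all four compounds, contributes, and whether a hydroxymethyl group in its place would preserve the step seen with chloro.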